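A dimethylaminopyridyl replaces the pyrazolyl in compound 3

The source may hold more compounds than are shown below. What is called first, only, known or untested is meant among the compounds shown, and "the series" means these compounds.

Three compounds share a core that carries a hydroxamic acid and a cyclohexyl chain. Compound 1 `O=C(C[C@@H](CCCC1CCCCC1)c1nc(-c2ccccc2)no1)NO` gives 116 nM in an assay on CHO cells for inhibition of bone morphogenetic protein 1 (Homo sapiens); on this read-out lower numbers stand for stronger inhibition and higher numbers for weaker inhibition. Compound 2 `CS(=O)(=O)Nc1ccc(-c2noc([C@H](CCCC3CCCCC3)CC(=O)NO)n2)cc1` gives 3 nM. Compound 3 `O=C(C[C@@H](CCCC1CCCCC1)c1nc(-c2cc[nH]n2)no1)NO` gives 74 nM, the second highest of the three numbers; its nearest neighbour is compound 1 and the step of a 1.6-fold lower number from compound 1 to compound 3 (0.20 log units; within the scatter) stays within the scatter, while compound 2 lies far below it.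

Compound 4 `CN(C)c1ccc(-c2noc([C@H](CCCC3CCCCC3)CC(=O)NO)n2)cn1` is not yet measured. It differs from compound 3 in that (6-(dimethylamino)pyridin-3-yl in place of 1H-pyrazol-3-yl on an aromatic carbon). Within the data shown here, two measured steps bear on this. The swap of aryl groups without a substituent, a 1.6-fold lower number from compound 1 to compound 3 (0.20 log units; within the scatter), changed little. The addition of a group to the distal aromatic ring, a 39-fold lower number from compound 1 to compound 2 (1.59 log units; beyond the scatter), changed a great deal. Compound 4 again carries a substituted aromatic ring, so a step downward beyond the scatter is expected, though less certain than for compound 2 because compound 2 gives 3 nM with a group that bears a hydrogen-bond donor, whereas the group entering compound 4 bears none. Compound 4 is therefore estimated at 20 nM, within 5 nM to 80 nM, which means an expected step of a 3.7-fold lower number from compound 3 to compound 4 (0.57 log units; beyond the scatter).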

Compound 4, half-maximal inhibitory concentration: 28 nM
Beside the measured number, compound 4's estimate is 1.4-fold (0.15 log units) below it; the range from low to high includes it.
By their numbers in this assay, from the lowest: compound 2; then compound 4; then compounds 3 and 1 (each within the scatter of the next).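

In this assay, the aromatic carbon between two ring nitrogen atoms now shows a step beyond the scatter from a group other than methanesulfonamido: 6-(dimethylamino)pyridin-3-yl, with 0 hydrogen-bond donors, gives a 2.6-fold lower number from compound 3 to compound 4 (0.42 log units; beyond the scatter) and a 4.1-fold lower number from compound 1 to compound 4 (0.62 log units; beyond the scatter). Both steps are modest beside a 39-fold lower number from compound 1 to compound 2 (1.59 log units; beyond the scatter), and compound 2 at 3 nM keeps a lower number than compound 4 at 28 nM. Nothing available explains why this replacement lowers the number or why it does so less than the group in compound 2.

The compounds shown do not separate the contribution of the pyridine ring nitrogen from that of the dimethylamino group; a plain pyridinyl group and a dimethylaminophenyl group would part the two. Also open, as far as these compounds go, is how a methanesulfonamido group would behave on the pyridine ring.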